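From Methylamino to Diethylamino on a Shared Core

The source may hold more compounds than are shown below. What is called first, only, known or untested is meant among the compounds shown, and "the series" means these compounds.

Three compounds have been measured in a functional assay on DU-145 cells (Homo sapiens) for cytotoxicity, read by MTT assay, with a stated time of 72 h; on this read-out lower numbers stand for stronger inhibition and higher numbers for weaker inhibition:
compound 1 `O=c1ccc2nc(-c3ccccc3)nn(-c3ccccc3)c-2c1` gives 230 nM;
compound 2 `CNc1cc2nc(-c3ccccc3)nn(-c3ccccc3)c-2cc1=O` gives 980 nM;
compound 3 `CCNc1cc2nc(-c3ccccc3)nn(-c3ccccc3)c-2cc1=O` gives 220 nM.

Compound 2 stands highest of the three numbers: the step of a 4.3-fold higher number from compound 1 to compound 2 (0.63 log units; beyond the scatter), and the step of a 4.5-fold lower number from compound 2 to compound 3 (0.65 log units; beyond the scatter), both lie beyond the scatter. Compound 4 `CCN(CC)c1cc2nc(-c3ccccc3)nn(-c3ccccc3)c-2cc1=O` differs from compound 2 in one place: diethylamino in place of methylamino on an aromatic carbon. The measured step that bears most on it is a 4.5-fold lower number from compound 2 to compound 3 (0.65 log units; beyond the scatter), where lengthening the chain on the nitrogen lowered the number, while a 1.0-fold lower number from compound 1 to compound 3 (0.02 log units; within the scatter) shows the ethylamino compound sitting with the unsubstituted one. Going by the values given here, no measured step adds a second chain, so the expectation rests on that single lowering. For compound 4 the expected step is a 2.8-fold lower number from compound 2 to compound 4 (0.45 log units; beyond the scatter), and its estimated value is 350 nM, within 120 nM to 1000 nM.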

Compound 4, half-maximal inhibitory concentration: 3110 nM
Compound 4: middle estimate off by 8.9-fold (0.95 log units), on the low side, outside the stated range (above it).
By their numbers in this assay, from the lowest: compounds 3 and 1 (each within the scatter of the next); then compound 2; then compound 4.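

Ethyl in place of hydrogen on the nitrogen gives a 14-fold higher number from compound 3 to compound 4 (1.15 log units; beyond the scatter), so the lowering seen on going from methylamino to ethylamino does not carry over to diethylamino. Diethylamino also stands above methylamino, with a 3.2-fold higher number from compound 2 to compound 4 (0.50 log units; beyond the scatter), and above hydrogen on this aromatic carbon, with a 14-fold higher number from compound 1 to compound 4 (1.13 log units; beyond the scatter), so the number does not move in one direction as the group grows. Diethylamino alone among these amino groups has no hydrogen-bond donor, but these compounds cannot separate that loss from the added carbons.

Nothing measured here accounts for the rise. On these data alone, whether propylamino, with one longer chain, or a pyrrolidine ring on this carbon would sit with compound 3 or with compound 4 remains open.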